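Trifluoromethoxy on the benzylamide ring of the valine series

This account rests on a few compounds, and the source may have more. Where it says the series, first, only, none or still open, it means among the compounds named here.

The three measured compounds share one core: compound 1 `Cc1ccc(CNC(=O)[C@H](N)C(C)C)cc1`, compound 2 `CC(C)[C@@H](N)C(=O)NCc1ccc(C(F)(F)F)cc1` and compound 3 `CC(C)[C@@H](N)C(=O)NCc1ccc(-c2ccccc2)cc1`. In a functional assay on the whole organism (strain albino Sprague-Dawley) with Rattus norvegicus as the target, in the maximal electroshock model (on this read-out lower numbers stand for an effect already at smaller amounts and higher numbers for an effect only at larger amounts of compound), compound 1 gives 50 mg/kg, compound 2 gives 13 mg/kg and compound 3 gives 30 mg/kg. Among the three numbers compound 3 stands second highest; its nearest neighbour is compound 1, and the gap between them lies within the scatter, while the gap to compound 2 lies beyond it. The steps show a 3.8-fold lower number from compound 1 to compound 2 (0.59 log units; beyond the scatter), a 1.7-fold lower number from compound 1 to compound 3 (0.22 log units; within the scatter) and a 2.3-fold higher number from compound 2 to compound 3 (0.36 log units; beyond the scatter).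

Compound 4 `CC(C)[C@@H](N)C(=O)NCc1ccc(OC(F)(F)F)cc1` is not yet measured. It differs from compound 3 in one place: trifluoromethoxy in place of phenyl on an aromatic carbon. Within the data shown here, no measured step involves trifluoromethoxy, so the nearest guides are the replacement of methyl by trifluoromethyl, which gave a 3.8-fold lower number from compound 1 to compound 2 (0.59 log units; beyond the scatter), and the replacement of trifluoromethyl by phenyl, which gave a 2.3-fold higher number from compound 2 to compound 3 (0.36 log units; beyond the scatter). Both steps put the fluorinated group at the lower end of the range in this assay. A lower number than compound 3, of modest size and likely beyond the scatter, is therefore expected for compound 4, as a 1.7-fold lower number from compound 3 to compound 4 (0.22 log units; within the scatter). The estimate for compound 4 in this assay is 18 mg/kg, with a range from 8 mg/kg to 40 mg/kg.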

Compound 4, dose for half-maximal effect: 18 mg/kg
Estimate against measurement, compound 4: no gap at the digits printed; the measured number falls inside the stated range.
By their numbers in this assay, from the lowest: compounds 2, 4, 3 and 1 (each within the scatter of the next, the first and the last beyond it).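

Trifluoromethoxy is the second group at this position, after trifluoromethyl, to separate clearly from methyl in this assay: the series shows a 2.8-fold lower number from compound 1 to compound 4 (0.44 log units; beyond the scatter), whereas phenyl gives only a 1.7-fold lower number from compound 1 to compound 3 (0.22 log units; within the scatter). The new compound does not sharpen the ranking of the larger groups, since a 1.4-fold higher number from compound 2 to compound 4 (0.14 log units; within the scatter) and a 1.7-fold lower number from compound 3 to compound 4 (0.22 log units; within the scatter) both remain within the scatter, so compound 4 cannot be told apart from either compound 2 or compound 3, even though those two differ beyond the scatter from each other and phenyl, unlike trifluoromethoxy, carries a ring. Nothing available explains why these groups compare as they do at this position.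

The compounds shown leave open whether fluorine is needed at this position at all, as a methoxy group, the direct non-fluorinated partner of trifluoromethoxy, and a single chlorine atom have no values here. They also leave open how a charged group such as an amine or a carboxylic acid, or a longer alkyl chain such as butyl, would fare on the same aromatic carbon.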